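A few compounds are considered here, and "the series" means these few. Any claim that something is new, unique, unknown or untested is made for them only; others in the source may bear on it.

Measured in a functional assay on HepG2 cells (Homo sapiens) for inhibition, read by MTT assay, with a stated time of 120 h; on this read-out lower numbers stand for stronger inhibition and higher numbers for weaker inhibition:
- compound 1 `CNC(=O)/C(C)=C/c1ccc(NC(=O)Nc2ccc(Cl)c(C(F)(F)F)c2)cc1`: 44300 nM
- compound 2 `O=C(CCc1ccc(NC(=O)Nc2ccc(Cl)c(C(F)(F)F)c2)cc1)NC1CCC1`: > 50000 nM

Compound 2 has no number on this assay, only a limit of the assay: > 50000 nM. That limit is the only position known for it, and the limit of > 50000 nM in this assay, at which 1 of the 2 values shown sits, applies.

Compound 3 `CNC(=O)/C=C(\C)c1ccc(NC(=O)Nc2ccc(Cl)c(C(F)(F)F)c2)cc1` is still unmeasured. It differs from compound 2 by a single exchange, with 1-methyl-2-(methylcarbamoyl)ethenyl in place of 2-(cyclobutylcarbamoyl)ethyl on an aromatic carbon.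

Among the measured compounds shown here, one measured step bears on this exchange: an at least 1.1-fold higher number from compound 1 to compound 2 (0.05 log units; that floor lies within the scatter). Its floor lies within the scatter, and its true size is open. On that basis, no step beyond the scatter is expected in this assay, and a further limit reading remains possible.

The estimated step is an at least 1.2-fold lower number from compound 2 to compound 3 (0.09 log units; that floor lies within the scatter).

The expected value for compound 3 is 40000 nM, with an estimated range of 15000 nM to 60000 nM.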

Compound 3, half-maximal inhibitory concentration: > 50000 nM
Compound 3 ended at the assay's limit (the forecaster's own chance of this, stated with the estimate: 35%); middle value at least 1.2-fold (0.09 log units) away from the limit.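

On these data alone, exchanging 2-(methylcarbamoyl)prop-1-en-1-yl for 1-methyl-2-(methylcarbamoyl)ethenyl, on an aromatic carbon para to a large group, gives in this assay an at least 1.1-fold higher number from compound 1 to compound 3 (0.05 log units; that floor lies within the scatter), so this change shows no step beyond the scatter and its true size stays open. The steps involving compound 2 and compound 3 together cannot be read, since both compounds carry limits of the assay and not numbers. Compound 3 adds a second compound at that ceiling, and the series now sits mostly there: the limit of > 50000 nM in this assay, at which 2 of the 3 values shown sit.

As far as these compounds go, whether a carboxylic acid, an amine or a longer chain at this position would give a reading clear of that limit stays open. From the compounds shown here alone, with compound 1 alone holding a number, the size of any change here also remains open.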